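Swapping a spiro piperidine for an isopropyl piperidine

The source may report more compounds than this note shows. Statements on the series, on what has been measured and on what is new or still open speak of the compounds shown alone.

Measured compounds:
compound 1, `COc1ccc2[nH]c(C(=O)N3CC(=O)N(Cc4ccccc4)[C@@H](CN4CCC5(CC4)CC5)C3)cc2c1`, 17100 nM
compound 2, `O=C(c1cc2cc(C3CC3)ccc2[nH]1)N1CC(=O)N(Cc2ccccc2)[C@@H](CN2CCN(Cc3ccccc3)CC2)C1`, 5500 nM
compound 3, `COc1ccc2[nH]c(C(=O)N3CC(=O)N(Cc4c[nH]c5ccccc45)[C@@H](Cc4ccccc4)C3)cc2c1`, 7200 nM

All three were tested in an ADME assay on Vero cells (Chlorocebus sabaeus) for cytotoxicity, with a stated time of 7 days; on this read-out lower numbers stand for higher toxicity in this test and higher numbers for lower toxicity in this test. Compound 1 has the highest number of the three, so it is the least toxic of this small set. Its nearest neighbour is compound 3, and the gap between them is already beyond the scatter of the measurement; the gap to compound 2 is larger still. Compound 4, `COc1ccc2[nH]c(C(=O)N3CC(=O)N(Cc4ccccc4)[C@@H](CN4CCC(C(C)C)CC4)C3)cc2c1`, has not yet been measured in this assay . It differs from compound 1 in one place: a group of 9 heavy atoms (8 carbon, 1 nitrogen; one six-membered non-aromatic ring with 1 hetero atom) in place of a group of 8 heavy atoms (7 carbon, 1 nitrogen; one three-membered non-aromatic ring of carbon only, one six-membered non-aromatic ring with 1 hetero atom), on a saturated chain carbon bound to a saturated ring carbon. The shared core and the benzyl group on the ring nitrogen are unchanged. Going by the values given here, no measured pair in this set shows a change of this kind, so there is nothing here to say how such a swap moves the number. Since the two groups are close in size and count, the step is expected to be small, a 1.2-fold lower number from compound 1 to compound 4 (0.09 log units; within the scatter), in no clear direction beyond the scatter. Compound 4 is therefore estimated at 14000 nM, with a range from 6000 nM to 35000 nM.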

Compound 4, half-maximal cytotoxic concentration: 3800 nM
For compound 4 the middle estimate is 3.7-fold (0.57 log units) above the measured one, outside the stated range (below it).
By their numbers in this assay, from the lowest: compounds 4, 2 and 3 (each within the scatter of the next); then compound 1.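

In this assay, the change on this saturated chain carbon gives a 4.5-fold lower number from compound 1 to compound 4 (0.65 log units; beyond the scatter). The step goes beyond the scatter, even though the two groups are close in heavy-atom count and have the same counts of hydrogen-bond donors and acceptors. The earlier compounds shown here included no pair differing in one place, and this pair now shows that toxicity in this test can respond to a small change in the amine group at this position. Nothing shown here gives a measured reason for the step.

On these data alone, it remains open whether the lower number goes with the arrival of the isopropyl group or the loss of the three-membered carbon ring. A plain piperidin-1-yl group or a morpholine at the same place could help separate these two readings.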